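Acetoxy in place of amino: what to expect

The compounds below may be only part of what the source reports. "The series", "measured", "known", "first", "only" and "open" are said of these compounds alone.

- compound 1 `NC1CCC(CN2CCN(c3cc(=O)c4cc(C(F)(F)F)cc([N+](=O)[O-])c4s3)CC2)CC1`: 107%
- compound 2 `O=c1cc(N2CCN(CC3CCC(NS(=O)(=O)c4ccccc4)CC3)CC2)sc2c([N+](=O)[O-])cc(C(F)(F)F)cc12`: 95.3%
- compound 3 `O=C(OC1CCC(CN2CCN(c3cc(=O)c4cc(C(F)(F)F)cc([N+](=O)[O-])c4s3)CC2)CC1)c1ccncc1`: 1.4%

In an ADME assay on cells (Hepatocyte, Mus musculus) for metabolic stability, with a stated time of 30 min (a higher number here means that more of the compound is left, a lower number that less of the compound is left), compound 1 stands highest of the three at 107%. Compound 4 `CC(=O)OC1CCC(CN2CCN(c3cc(=O)c4cc(C(F)(F)F)cc([N+](=O)[O-])c4s3)CC2)CC1` has not been measured yet and differs from compound 1 in one place: acetoxy in place of amino on a saturated ring carbon. Put simply, acetoxy takes the place of amino on a saturated ring carbon.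

The closest measured change is a number 105.6 percentage points lower from compound 1 to compound 3 (beyond the scatter), with ((pyridin-4-yl)carbonyl)oxy in place of amino, which is a large step. Like acetoxy, that group joins a carbonyl to the ring through oxygen. The step of a number 93.9 percentage points lower from compound 2 to compound 3 (beyond the scatter) is also large and ends at the same compound. By contrast, a number 11.7 percentage points lower from compound 1 to compound 2 (beyond the scatter) keeps nitrogen on the ring and is only modest. For the measured compounds named here, this is a thin basis, resting on compound 3 alone, and no measured compound carries acetoxy itself.

A large downward step is therefore expected in this assay. The expected change is a number 101 percentage points lower from compound 1 to compound 4 (beyond the scatter). For compound 4 the estimated value is 6%, with an expected range of 0% to 35%.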

Compound 4, percent of the compound remaining: 0%
For compound 4 the middle estimate is 6 percentage points above the measured one; low and high end bracket the measured number.
By their numbers in this assay, from the lowest: compounds 4 and 3 (each within the scatter of the next); then compound 2; then compound 1.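

In this assay, acetoxy in place of amino gives a number 107 percentage points lower from compound 1 to compound 4 (beyond the scatter) and so shows that the pyridin-4-yl group of compound 3 is not needed for a very low number at this saturated ring carbon. Methyl in place of pyridin-4-yl on the carbonyl carbon gives a number 1.4 percentage points lower from compound 3 to compound 4 (within the scatter) and so makes no readable difference here. Acetoxy in place of (phenylsulfonyl)amino gives a number 95.3 percentage points lower from compound 2 to compound 4 (beyond the scatter) and so extends the split across all four compounds: compound 1 and compound 2, with nitrogen on the ring, stand high, while compound 3 and compound 4, with a carbonyl joined through oxygen, stand very low.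

Still open, from the compounds shown here alone, is whether the oxygen link, the carbonyl or both go with the low numbers, which a plain hydroxyl, an ether or an amide on the same carbon could help separate. Nothing measured here gives a reason for the fall.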